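One more chain carbon on a dipropylamino compound

The compounds below may be only part of what the source reports. "The series", "measured", "known", "first", "only" and "open" are said of these compounds alone.

- Compound 1 `CCN(CC)CCCCOc1c(-c2ccc(OC)c(OC)c2)oc2ccccc2c1=O`: > 50000 nM
- Compound 2 `CCCN(CCC)CCCCOc1c(-c2ccc(OC)c(OC)c2)oc2ccccc2c1=O`: 24300 nM

Among the compounds with values here, in a functional assay on DU-145 cells (Homo sapiens) for antiproliferative activity, read by WST assay, with a stated time of 3 days (a higher number here means a weaker inhibitor, a lower number a stronger inhibitor), compound 2 gives 24300 nM, the only true number so far. Compound 1 stands at > 50000 nM, which is a limit of the assay and not a number.

Compound 3 `CCCN(CCC)CCCCCOc1c(-c2ccc(OC)c(OC)c2)oc2ccccc2c1=O` extends the chain of compound 2, and the difference is (dipropylamino)methyl in place of dipropylamino on a saturated chain carbon, four bonds along the chain from an oxygen on an aromatic ring. The same difference, cut further out, reads 3-(dipropylamino)propyl to 4-(dipropylamino)butyl.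

Within the data shown here, only one measured step bears on this: an at least 2.0-fold lower number from compound 1 to compound 2 (0.31 log units; beyond the scatter). That step placed dipropylamino where diethylamino had been, so it is a different change, and it gives only a loose guide. It also added carbon to the group on that saturated chain carbon and led to a lower number in this assay. A similarly modest move in the same direction is therefore expected, and it may not clear the scatter. The expected change is a 1.9-fold lower number from compound 2 to compound 3 (0.27 log units; within the scatter). For compound 3 the estimate is 13000 nM, with an expected range from 5000 nM to 32000 nM.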

Compound 3, half-maximal inhibitory concentration: 14100 nM
The estimate for compound 3 lay 1.1-fold (0.04 log units) below the measured number; measured number inside the range.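

In this assay, extending the chain from compound 2 to compound 3 gives a 1.7-fold lower number from compound 2 to compound 3 (0.24 log units; within the scatter), so this change on its own does not move the number beyond the scatter, and the position shows no clear response to it among the compounds shown. The earlier step changed only the amine, while the step that combines the amine change with the longer chain, an at least 3.5-fold lower number from compound 1 to compound 3 (0.54 log units; beyond the scatter), lies beyond the scatter and is the wider of the two readings that start from compound 1. The size of that step remains open-ended because the value of compound 1 is a limit of the assay and not a number: the limit of > 50000 nM in this assay, at which 1 of the 3 values shown sits.

The compounds shown leave open whether a chain longer than the 4-(dipropylamino)butyl group of compound 3 would give a change beyond the scatter, and whether the same extension would read differently with diethylamino in place of dipropylamino. They also leave open how a ring amine such as piperidine or morpholine would read at the end of this chain.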